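The source may report more compounds than this note shows. Statements on the series, on what has been measured and on what is new or still open speak of the compounds shown alone.

Among the measured compounds shown here, in a functional assay on A549 cells (Homo sapiens) for antiproliferative activity, read by MTT assay, with a stated time of 72 h (on this read-out lower numbers stand for stronger inhibition and higher numbers for weaker inhibition), compound 1 `NC1=NC2(CCOCC2)N(OCCCOc2ccc(Cl)cc2)C(N)=N1` gives 360 nM and compound 2 `NC1=NC2(CCOCC2)N(OCCCOc2ccccc2Cl)C(N)=N1` gives 2700 nM, while compound 3 `NC1=NC2(CCOCC2)N(OCCCOc2ccc(Cl)c(Cl)c2)C(N)=N1` stands between them at 790 nM among the three numbers so far. The change to compound 4 `NC1=NC2(CCOCC2)N(OCCCOc2cccc(Br)c2)C(N)=N1`, not yet measured, is 3-bromophenyl in place of 3,4-dichlorophenyl on an oxygen on a saturated carbon on an oxygen on a saturated carbon. For the measured compounds named here, two measured steps bear on it: a 7.5-fold higher number from compound 1 to compound 2 (0.88 log units; beyond the scatter) for 2-chlorophenyl in place of 4-chlorophenyl, and a 2.2-fold higher number from compound 1 to compound 3 (0.34 log units; beyond the scatter) for chloro in place of hydrogen on an aromatic carbon. Going by the values given here, no measured compound carries 3-bromophenyl, and with the modest step of a 2.2-fold higher number from compound 1 to compound 3 (0.34 log units; beyond the scatter) as the closest guide, no step beyond the scatter is expected in this assay for this change. The expected step is a 1.0-fold higher number from compound 3 to compound 4 (0.01 log units; within the scatter) with no firm direction. Compound 4 is estimated at 800 nM with 300 nM and 2200 nM as the expected lower and upper ends.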

Compound 4, half-maximal inhibitory concentration: 160 nM
For compound 4 the middle estimate is 5.0-fold (0.70 log units) above the measured one; the whole stated range lies above it.
By their numbers in this assay, from the lowest: compound 4; then compound 1; then compound 3; then compound 2.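

In this assay, 3-bromophenyl on this oxygen gives the lowest number of the four compounds, with a 4.9-fold lower number from compound 3 to compound 4 (0.69 log units; beyond the scatter), a 2.3-fold lower number from compound 1 to compound 4 (0.35 log units; beyond the scatter) and a 17-fold lower number from compound 2 to compound 4 (1.23 log units; beyond the scatter). The 4-chlorophenyl group of compound 1 therefore no longer marks the best result here, and a single halogen on the phenyl ring can give either the lowest number, in compound 4, or the highest, in compound 2. Nothing available explains this order. Going by these compounds, in compound 4 the halogen and its ring position change together, so it remains open how 3-chlorophenyl would compare. On these data alone, how a methoxy group or an amine on the ring, or a longer chain, would read also remains open.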